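This account rests on a few compounds, and the source may have more. Where it says the series, first, only, none or still open, it means among the compounds named here.

In a functional assay on JC cells (Mus musculus) for inhibition, read by sulforhodamine B assay, with a stated time of 48 h (on this read-out lower numbers stand for stronger inhibition and higher numbers for weaker inhibition), the measured compounds stand as follows:

compound 1, `COc1cc(Cn2cc(CCc3cc(OC)c(OC)c(OC)c3)c3c(C)nc(N)nc32)cc(OC)c1`: 3000 nM
compound 2, `COc1cc(CCc2cn(Cc3cc(OC)c(OC)c(OC)c3)c3nc(N)nc(C)c23)cc(OC)c1OC`: 1000 nM
compound 3, `COc1ccccc1Sc1cn(Cc2ccccc2)c2nc(N)nc(C)c12`: 11000 nM

The step of a 3.0-fold lower number from compound 1 to compound 2 (0.48 log units; beyond the scatter) goes with the change (methoxy in place of hydrogen on an aromatic carbon). Compound 3 gives the highest number of the three. How the core of compound 3 differs from the core of compound 1 is not broken down here.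

Compound 4, `COc1ccccc1Cn1cc(Sc2ccccc2OC)c2c(C)nc(N)nc21`, is still to be measured in this assay. It differs from compound 3 by methoxy in place of hydrogen on an aromatic carbon. This is the same kind of change as that from compound 1 to compound 2, not the same: there the entering methoxy sits ortho to two methoxy groups and para to a large group, here it sits ortho to a large group. Because a 3.0-fold lower number from compound 1 to compound 2 (0.48 log units; beyond the scatter) is only modest and the surroundings of the place differ, a smaller step is expected for compound 4: a 2.0-fold lower number from compound 3 to compound 4 (0.30 log units; within the scatter). Compound 4 is therefore estimated at 5500 nM, expected to fall between 2000 nM and 15000 nM.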

Compound 4, half-maximal inhibitory concentration: 9000 nM
For compound 4 the middle estimate is 1.6-fold (0.21 log units) below the measured one; low and high end bracket the measured number.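

In this assay, methoxy in place of hydrogen on an aromatic carbon gives a 1.2-fold lower number from compound 3 to compound 4 (0.09 log units; within the scatter), a step that does not stand out from the scatter on its own. Set beside the earlier step, it does not differ from it by more than the scatter of two such steps: the same change on two cores in this assay, a 3.0-fold lower number (0.48 log units; beyond the scatter) from compound 1 to compound 2 and a 1.2-fold lower number (0.09 log units; within the scatter) from compound 3 to compound 4, 2.5-fold (0.39 log units) apart, within the scatter of two such steps. The change may therefore carry across these two cores, but two pairs with the methoxy in different surroundings do not establish one step size for the series, and they do not show that the change lowers the number on the core of compound 3.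

The compounds shown leave open how an amine or a carboxylic acid would read at the same place, ortho to a large group. They also leave open whether a longer chain in place of methoxy would give a step beyond the scatter on either core.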